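The source may report more compounds than this note shows. Statements on the series, on what has been measured and on what is new or still open speak of the compounds shown alone.

Measured in a functional assay on HL-60 cells (Homo sapiens) for antiproliferative activity, read by XTT assay, with a stated time of 72 h; on this read-out higher numbers stand for weaker inhibition and lower numbers for stronger inhibition:
- Compound 1 `COc1ncnc2c1c(-c1ccccc1)cn2[C@@H]1O[C@H](CO)[C@@H](O)[C@H]1O`: > 20000 nM, a limit of the assay
- Compound 2 `COc1ncnc2c1c(-c1cc3ccccc3o1)cn2[C@@H]1O[C@H](CO)[C@@H](O)[C@H]1O`: 4470 nM
- Compound 3 `CNc1ncnc2c1c(-c1ccco1)cn2[C@@H]1O[C@H](CO)[C@@H](O)[C@H]1O`: 620 nM

Compound 3, at 620 nM, holds the lower of the two actual numbers, and compound 2 stands at 4470 nM. The gap between these two numbers lies beyond the scatter. Compound 4 `CNc1ncnc2c1c(-c1cccs1)cn2[C@@H]1O[C@H](CO)[C@@H](O)[C@H]1O` carries thiophen-2-yl in place of furan-2-yl on an aromatic carbon. Within the data shown here, only one measured step is available, an at least 4.4-fold lower number from compound 1 to compound 2 (0.65 log units; beyond the scatter), and it swaps phenyl for 1-benzofuran-2-yl, so it bears only loosely on this change. No step beyond the scatter is therefore expected in this assay. The expected change is a 1.0-fold lower number from compound 3 to compound 4 (0.01 log units; within the scatter). Compound 4 is estimated at 600 nM, within an expected range from 200 nM to 2000 nM.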

Compound 4, half-maximal inhibitory concentration: > 20000 nM
Compound 4: a limit, no number (the forecaster's own chance of this, stated with the estimate: 3%); middle value at least 33-fold (1.52 log units) from the limit.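

In this assay, the place on the shared core proves far from tolerant of a swap between two five-membered aromatic rings of equal heavy-atom count, with sulfur entering for oxygen: the change gives an at least 32-fold higher number from compound 3 to compound 4 (1.50 log units; beyond the scatter). Compound 4 gives > 20000 nM, which is a limit and not a number. The full size of the step stays unknown because the read-out ends there: the limit of > 20000 nM in this assay, at which 2 of the 4 values shown sit.

Left open is how furan-3-yl, thiophen-3-yl or oxazol-2-yl would fare at this place. From the compounds shown here alone, it is also open whether thiophen-2-yl behaves alike with methoxy in place of the methylamino group.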